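Removing one methoxy group from compound 2

A few compounds are considered here, and "the series" means these few. Any claim that something is new, unique, unknown or untested is made for them only; others in the source may bear on it.

Measured in a functional assay on KB cells (Homo sapiens) for inhibition; on this read-out lower numbers stand for stronger inhibition and higher numbers for weaker inhibition:
- compound 1 `NC(=S)c1c(N)n(COCc2ccccc2)c2ncnc(N)c12` gives 225000 nM as its value
- compound 2 `COc1ccc(Cn2c(N)c(C#N)c3c(N)ncnc32)cc1` gives 50000 nM as its value
- compound 3 `CCOCn1cc(C#N)c2c(N)ncnc21` gives > 100000 nM as a limit, not a number

Of the two compounds with true numbers, compound 2 has the lower, and its gap to compound 1 lies beyond the usual scatter. Compound 4 `N#Cc1c(N)n(Cc2ccccc2)c2ncnc(N)c12` has not yet been measured. It differs from compound 2 in one place: hydrogen in place of methoxy on an aromatic carbon, para to a large group. Among the measured compounds shown here, no two measured compounds differ in only one place, so the data offer no direct guide to this change. With compound 2 at 50000 nM as the starting point, only a small change in this assay is expected, slightly upward if anything, and possibly none beyond the scatter. The estimated change is a 1.2-fold higher number from compound 2 to compound 4 (0.08 log units; within the scatter) in this case. For compound 4 the expected value is 60000 nM with an estimated range from 25000 nM to 150000 nM in this assay.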

Compound 4, half-maximal inhibitory concentration: 34000 nM
Compound 4: the middle estimate sits 1.8-fold (0.25 log units) above what was measured; measured number inside the range.
By their numbers in this assay, from the lowest: compounds 4 and 2 (each within the scatter of the next); then compound 1.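

In this assay, taking the methoxy group away gives a 1.5-fold lower number from compound 2 to compound 4 (0.17 log units; within the scatter). This is the only direct reading of a single change among these compounds: on an aromatic carbon para to a large group, hydrogen can stand in place of methoxy with no shift that can be told apart from the scatter, so the methoxy group is not needed to hold inhibition at this level. Compound 3 gives only a limit, not a number, and so adds no comparison for this change: the limit of > 100000 nM in this assay, at which 1 of the 4 values shown sits.

As far as these compounds go, what an amine, a carboxylic acid or a longer chain would do at this same position remains open. From the compounds shown here alone, it is also open whether the same swap would stay this quiet on another carbon of the ring.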